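The source may hold more compounds than are shown below. What is called first, only, known or untested is meant among the compounds shown, and "the series" means these compounds.

Of the compounds shown here, two have numbers so far. Compound 1, `O=c1cc(-c2ccccc2)oc2cc(N3COc4ccccc4C3)ccc12`, and compound 2, `O=c1cc(-c2ccccc2)oc2ccc(N3COc4ccccc4C3)cc12`, are built from the same parts, joined to the shared core in a different arrangement. In a functional assay on MCF7 cells (Homo sapiens) for inhibition, read by MTT assay, with a stated time of 48 h, tested at 7.5 ug/mL (on this read-out lower numbers stand for less inhibition of growth and higher numbers for more inhibition of growth at the one concentration tested), compound 1 gives 2.65%, while compound 2 gives 8.7%. Compound 1 thus holds the lowest of the two numbers, but the gap to compound 2 falls within the usual scatter of repeated runs, so neither can be called weaker or stronger; both produce little inhibition of growth at the one concentration tested.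

Compound 3, `Cc1cccc2c1OCN(c1ccc3c(=O)cc(-c4ccccc4)oc3c1)C2`, is compound 1 carrying a single change: methyl in place of hydrogen on an aromatic carbon. Within the data shown here, no measured pair shows what this change does, so nothing can be read off directly. A small change of this kind is expected to move the result in this assay little, and the estimated step of a number 2.4 percentage points higher from compound 1 to compound 3 (within the scatter) is expected to stay inside the scatter, because compound 1 already gives only 2.65% and leaves little room to drop further. Compound 3 is therefore estimated at 5%, with a plausible range from 0% to 16%.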

Compound 3, percent growth inhibition at one concentration: 43.9%
Compound 3: the middle estimate sits 38.9 percentage points below what was measured, and the stated range ends below it.
By their numbers in this assay, from the lowest: compounds 1 and 2 (each within the scatter of the next); then compound 3.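

Methyl in place of hydrogen on an aromatic carbon gives a number 41.3 percentage points higher from compound 1 to compound 3 (beyond the scatter) in this assay, so a single added carbon at this place, ortho to a fused ring and meta to a fused ring, is enough to turn a compound with little inhibition of growth into one with clear inhibition at the one concentration tested. Compounds 1 and 2, whose numbers lie within the scatter of each other, gave no sign that this part of the molecule could matter so much. Nothing available here explains how the methyl produces this step.

From the compounds shown here alone, whether the step belongs to methyl itself or would also come with another group at this place stays open, and an ethyl, a methoxy group, a chlorine atom or a hydroxyl group there would help to separate those possibilities. Also open, going by these compounds, is whether the same methyl would do the same in the arrangement of compound 2, and how the compounds would compare across a range of concentrations rather than at a single one.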